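The compounds below may be only part of what the source reports. "The series", "measured", "known", "first", "only" and "open" are said of these compounds alone.

Compound 1 `COc1cc(N2CCN(Cc3ccccn3)CC2)ccc1Nc1nc(NC2CCCCC2)c2nc[nH]c2n1` gives 51 nM 
Compound 2 `COc1cc(N2CCC(C(=O)N3CCC(N(C)C)C3)CC2)ccc1Nc1nc(NC2CCCCC2)c2nc[nH]c2n1` gives 58 nM 

Within the data shown here, both values come from a functional assay on HCT-116 cells (Homo sapiens) for cytotoxicity (a lower number here means a stronger inhibitor, a higher number a weaker inhibitor), and lie within the scatter of each other, so compound 2 cannot be separated from compound 1, its only neighbour on the numbers.

The next compound, compound 3 `COc1cc(N2CCC(C(=O)N3CCOCC3)CC2)ccc1Nc1nc(NC2CCCCC2)c2nc[nH]c2n1`, keeps the shared core of compound 2 and changes one group: morpholin-4-yl in place of 3-(dimethylamino)pyrrolidin-1-yl on a carbonyl carbon. Among the measured compounds shown here, no measured pair differs in a single place, so this change has no direct precedent. Compound 1 (51 nM) and compound 2 (58 nM) carry different groups on the shared core, yet their values fall within the scatter, which gives no sign of a large step. In this assay a modest move towards a higher number, meaning a weaker inhibitor, is expected, at about the edge of the scatter. This direction is a judgement with little support from the data. The expected change is a 1.9-fold higher number from compound 2 to compound 3 (0.28 log units; within the scatter) (an estimate). Compound 3 is estimated at 110 nM (expected range 35 nM to 350 nM).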

Compound 3, half-maximal inhibitory concentration: 50 nM
Beside the measured number, compound 3's estimate is 2.2-fold (0.34 log units) above it; the measured number falls inside the stated range.
By their numbers in this assay, from the lowest: compounds 3, 1 and 2 (each within the scatter of the next).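

In this assay, among these compounds, placing morpholin-4-yl in place of 3-(dimethylamino)pyrrolidin-1-yl on a carbonyl carbon gives a 1.2-fold lower number from compound 2 to compound 3 (0.06 log units; within the scatter), the first comparison here between compounds that differ in one place. At this place, where the carbonyl carbon's other neighbour is a saturated ring carbon, the two groups cannot be told apart, even though one has 8 heavy atoms and a five-membered ring and the other has 6 heavy atoms and a six-membered ring with 2 hetero atoms. Nothing available bears on why the two values match.

The compounds shown leave open whether the number stays the same for every group on this carbonyl carbon or only for these two rings, and an open-chain amine such as diethylamine, a piperazine, or a carboxylic acid in place of the amide would speak to that. They also leave open whether a change elsewhere on the shared core, such as a cyclopentyl or phenyl group in place of the cyclohexyl group, would move the number beyond the scatter.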